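Fluorine on the Chain: What to Expect for Compound 3

This account rests on a few compounds, and the source may have more. Where it says the series, first, only, none or still open, it means among the compounds named here.

Compound 1, `Cn1c(-c2ccccc2C(F)(F)F)nnc1C12CCC(CCS(=O)(=O)C(C)(C)C)(CC1)CC2`: 65%
Compound 2, `CCCCCC12CCC(c3nnc(-c4ccccc4C(F)(F)F)n3C)(CC1)CC2`: 98%

Both compounds were tested in a functional assay on the whole organism (strain ICR) for inhibition, with Mus musculus as the target, with a stated time of 4 h, at a dose of 10 mg/kg by the oral route; a lower number here means less inhibition, a higher number more inhibition at the dose given (going by the name of the read-out). Compound 2 stands highest of the two numbers; its nearest neighbour, compound 1, lies well below it, and that gap is beyond the scatter. Going by the values given here, the only step measured so far, a number 33 percentage points higher from compound 1 to compound 2 (beyond the scatter), came from a different kind of change, a propyl in place of a (tert-butyl)sulfonyl on the chain.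

Compound 3 `CC(F)CCCC12CCC(c3nnc(-c4ccccc4C(F)(F)F)n3C)(CC1)CC2` differs from compound 2 by fluoro in place of hydrogen on a saturated chain carbon bound to two saturated chain carbons. Among the compounds with values here, no measured step involves a fluoro entering on a saturated chain carbon bound to two saturated chain carbons, so nothing here shows how such a change moves this assay. The large step from compound 1 to compound 2 does not bear on it directly. With compound 2 already near the top of the percentage scale, little room remains upward, and a small change is the plainest expectation.

Compound 3 is therefore expected to give about 92%, with a likely range from 75% to 100%, meaning an expected step of a number 6 percentage points lower from compound 2 to compound 3 (within the scatter) in this assay.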

Compound 3, a percentage reported as inhibition, in the whole organism at one dose (the size of the read-out at that dose, not a potency): 96%
The estimate for compound 3 lay 4 percentage points below the measured number, and the stated range covers the measured number.
By their numbers in this assay, from the lowest: compound 1; then compounds 3 and 2 (each within the scatter of the next).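

In this assay, a fluoro in place of hydrogen on a saturated chain carbon bound to two saturated chain carbons gives a number 2 percentage points lower from compound 2 to compound 3 (within the scatter), so at this single dose the chain takes this one fluorine with no change that can be told from the scatter. The large gap to the sulfonyl-bearing compound also remains with fluorine on the chain, as a number 31 percentage points higher from compound 1 to compound 3 (beyond the scatter) shows, but compound 2 and compound 3 both sit near the top of the percentage scale, where a gain would have little room to appear and a real difference between them could stay hidden. No further data are available to explain why the fluoro leaves the read-out in this place.

As far as these compounds go, it remains open whether a second fluorine on the same carbon, a hydroxyl group there, or an amine on the chain would be accepted as well. From the compounds shown here alone, it is also open whether fluoro on another chain carbon, or a longer chain carrying fluorine, would give the same picture.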